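A few compounds are considered here, and "the series" means these few. Any claim that something is new, unique, unknown or untested is made for them only; others in the source may bear on it.

In an ADME assay on HEK293 cells (Homo sapiens) for cytotoxicity, read by MTT assay, with a stated time of 72 h (a lower number here means a stronger inhibitor, a higher number a weaker inhibitor), three compounds have been tested so far, and none of them has yielded a number. Compound 1 `COc1ccc(C2=C(c3cc(OC)c(OC)c(OC)c3)C(=O)CC2O[SiH2]C(C)(C)C)cc1` gives > 100 ug/mL, which is a limit of the assay. Compound 2 `COc1cc(C2=C(c3cc(C)c(OC)c(C)c3)C(O)CC2=O)cc(OC)c1OC` gives > 100 ug/mL, again a limit. Compound 3 `COc1ccc(C2=C(c3cc(OC)c(OC)c(OC)c3)C(=O)CC2O[SiH2]C(C)(C)C)cc1OC` gives > 100 ug/mL, also a limit. Compound 3 therefore has no measured position of its own and stands with the others at the limit of > 100 ug/mL in this assay, at which 3 of the 3 values shown sit.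

The next step leads to compound 4 `COc1cc(C2=C(c3cc(C)c(OC)c(C)c3)C(O[SiH2]C(C)(C)C)CC2=O)cc(OC)c1OC`. The change is 4-methoxy-3,5-dimethylphenyl in place of 3,4-dimethoxyphenyl on a double-bonded ring carbon. For the measured compounds named here, the only measured step that touches this aromatic group is a step that the two limits leave unreadable from compound 1 to compound 3, where methoxy replaces hydrogen on an aromatic carbon. It has no readable size, so it offers no measured effect to carry over to the new group. With nothing pointing in either direction, no shift beyond the usual scatter is expected in this assay, and the assay will probably report only a limit again. The expected change is a step that the limit leaves unreadable from compound 3 to compound 4. For compound 4 the estimated value is 130 ug/mL, with an expected range of 60 ug/mL to 300 ug/mL.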

Compound 4, half-maximal inhibitory concentration: 29 ug/mL
The estimate for compound 4 lay 4.5-fold (0.65 log units) above the measured number; the whole stated range lies above it.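

On the double-bonded ring carbon, 4-methoxy-3,5-dimethylphenyl gives an at least 3.4-fold lower number from compound 3 to compound 4 (0.53 log units; beyond the scatter) in this assay when it replaces 3,4-dimethoxyphenyl and an at least 3.4-fold lower number from compound 1 to compound 4 (0.53 log units; beyond the scatter) when it replaces 4-methoxyphenyl, so the aromatic group at this position can shift the result, which the unreadable earlier step could not show. The change on the oxygen on a saturated carbon matters as well: a group of 5 heavy atoms (4 carbon, 1 silicon; no ring) in place of a hydrogen atom gives an at least 3.4-fold lower number from compound 2 to compound 4 (0.53 log units; beyond the scatter). Among the compounds shown, neither change alone yields a measured number, since only compound 4 carries both, and the other compounds remain at a limit of the assay: the limit of > 100 ug/mL in this assay, at which 3 of the 4 values shown sit.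

From the compounds shown here alone, the true sizes of these steps remain open, as does the question of whether the two methyl groups or the loss of a ring methoxy drives the aromatic step. It is also unknown whether a smaller group on that oxygen, such as methyl or acetyl, or chlorine in place of the two aromatic methyl groups, would give a measurable number in this assay.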